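The source may hold more compounds than are shown below. What is called first, only, known or untested is meant among the compounds shown, and "the series" means these compounds.

Four compounds share one core and differ only in the group on a saturated chain carbon bound to an amide-type nitrogen and a carbonyl carbon. Compound 1 `O=C(N[C@@H](CO)C(=O)NO)c1ccc(C#Cc2ccccc2)cc1` gives 2 in a physicochemical assay for lipophilicity; a higher number here means a more lipophilic compound, a lower number a more polar compound. Compound 2 `NC(=O)C[C@H](NC(=O)c1ccc(C#Cc2ccccc2)cc1)C(=O)NO` gives 1 in this assay, and compound 3 `O=C(N[C@H](CO)C(=O)NO)c1ccc(C#Cc2ccccc2)cc1` gives 2. Compound 3 therefore stands level with compound 1 and, together with it, at the top of the three numbers, while compound 2 sits lowest, since a number 1.00 log units lower from compound 1 to compound 2 (beyond the scatter). That compounds 1 and 3 read alike fits (the fact that compounds 1 and 3 differ only in the configuration as drawn), with no change at the digits printed from compound 1 to compound 3 (within the scatter). Compound 4 `O=C(CNC(=O)c1ccc(C#Cc2ccccc2)cc1)NO` has not been measured yet; the change from compound 3 is hydrogen in place of hydroxymethyl on a saturated chain carbon bound to an amide-type nitrogen and a carbonyl carbon. Neither measured step removes the whole group: one exchanges hydroxy for carbamoyl and the other only turns the configuration, so neither fixes the size of this step, and only a cautious guess is possible. The expected outcome is a small rise, a number 0.50 log units higher from compound 3 to compound 4 (beyond the scatter), which places compound 4 at an estimated 2.5, somewhere between 2.1 and 2.9.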

Compound 4, distribution coefficient: 3
Beside the measured number, compound 4's estimate is 0.50 log units below it; the whole stated range lies below it.
By their numbers in this assay, from the lowest: compound 2; then compounds 1 and 3 (each within the scatter of the next); then compound 4.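

Of the steps at this position, only those to compound 4 raise the number in this assay: hydrogen in place of hydroxymethyl gives a number 1.00 log units higher from compound 3 to compound 4 (beyond the scatter), and the same exchange gives a number 1.00 log units higher from compound 1 to compound 4 (beyond the scatter). The two steps match whichever configuration the hydroxymethyl is drawn in, which fits one point: the fact that compounds 1 and 3 differ only in the configuration as drawn. Hydrogen in place of carbamoylmethyl gives the widest gap of the set, a number 2.00 log units higher from compound 2 to compound 4 (beyond the scatter), so compound 4, with hydrogen on this carbon, stands above all three compounds that carry a group there.

From the compounds shown here alone, what a methyl group or a longer chain would give on this carbon stays open, as does an amine or a carboxylic acid at the end of the group. With only hydroxymethyl and carbamoylmethyl to set against hydrogen, it remains unclear whether the number follows the size of the group or its kind.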